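A few compounds are considered here, and "the series" means these few. Any claim that something is new, unique, unknown or untested is made for them only; others in the source may bear on it.

The series shares one core, seen in compound 1 `O=C(O)/C=C/C(=O)Nc1cccc(-c2nc3ccccc3s2)c1` and compound 2 `CC(C)(CCl)C(=O)Nc1cccc(-c2nc3ccccc3s2)c1`, and both have been tested in an ADME assay on HepG2 cells (Homo sapiens) for inhibition, with a stated time of 72 h; on this read-out higher numbers stand for an effect only at larger amounts of compound and lower numbers for an effect already at smaller amounts. For compound 1 the result in this assay is a limit of the assay, > 25000 nM. For compound 2 the result in this assay is likewise a limit of the assay, > 25000 nM. For the measured compounds named here, the one measured step, a step that the two limits leave unreadable from compound 1 to compound 2, therefore cannot be read in size, and compound 2 stands at the same limit as its only neighbour, as the limit of > 25000 nM in this assay, at which 2 of the 2 values shown sit, records.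

Compound 3 `O=C(Nc1cccc(-c2nc3ccccc3s2)c1)c1ccnc(Cl)c1` differs from compound 2 in one place: 2-chloropyridin-4-yl in place of 1-(chloromethyl)-1-methylethyl on a carbonyl carbon. Going by the values given here, the only step that bears on this change is a step that the two limits leave unreadable from compound 1 to compound 2, and it offers no readable size, so no direction beyond the scatter can be argued from it. The expectation is that the step from compound 2 to compound 3 in this assay is a step that the limit leaves unreadable from compound 2 to compound 3, meaning no readable movement. Compound 3 is accordingly estimated at 40000 nM in this assay, with a range from 10000 nM to 160000 nM, most probably reported again as a limit.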

Compound 3, half-maximal effective concentration: > 25000 nM
Compound 3 ended at the assay's limit; the forecaster's own chance of this, stated with the estimate: 75%; the middle value is on the limit's open side.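

In this assay compound 3 gives > 25000 nM, a limit of the assay, so neither the step from compound 1 nor the step from compound 2 to it can be read in size. The compounds shown leave open whether any group on the carbonyl carbon of the shared core gives a readable value in this assay, since all three share one result: the limit of > 25000 nM in this assay, at which 3 of the 3 values shown sit.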